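Methyl in place of hydrogen on the amine nitrogen: compound 4

A few compounds are considered here, and "the series" means these few. Any claim that something is new, unique, unknown or untested is made for them only; others in the source may bear on it.

Measured so far in a functional assay on the whole organism with Mus musculus as the target; on this read-out lower numbers stand for an effect already at smaller amounts and higher numbers for an effect only at larger amounts of compound:
compound 1, `CC(C)NCc1nnc(-c2ccccc2-c2ccccc2)s1`, 35 mg/kg
compound 2, `NCc1nnc(-c2ccccc2-c2ccccc2)s1`, 22 mg/kg
compound 3, `CNCc1nnc(-c2ccccc2-c2ccccc2)s1`, 20 mg/kg

Compound 3 has the lowest of the three numbers in this assay, but it is separated from compound 2 by only a step within the scatter, and the difference to compound 1, a 1.8-fold lower number from compound 1 to compound 3 (0.24 log units; within the scatter), is also within the scatter. On these numbers nothing beyond the scatter separates the three.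

Compound 4, `CN(C)Cc1nnc(-c2ccccc2-c2ccccc2)s1`, is the next member. Its difference from compound 3 is methyl in place of hydrogen on an amine nitrogen.

The step that bears on this change most directly is a 1.1-fold lower number from compound 2 to compound 3 (0.04 log units; within the scatter), a change of the same kind on the same nitrogen, and it stayed within the scatter. The other two steps, a 1.6-fold lower number from compound 1 to compound 2 (0.20 log units; within the scatter) and a 1.8-fold lower number from compound 1 to compound 3 (0.24 log units; within the scatter), which also vary only the group on the amine nitrogen, were within the scatter as well. Among the compounds with values here, the series so far gives no sign that the substitution on this nitrogen moves the number in this assay beyond the scatter in either direction.

Compound 4 is therefore expected to give about 22 mg/kg in this assay, with a range of 12 mg/kg to 42 mg/kg. The expected step from compound 3 is a 1.1-fold higher number from compound 3 to compound 4 (0.04 log units; within the scatter), within the scatter.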

Compound 4, dose for half-maximal effect: 35 mg/kg
Beside the measured number, compound 4's estimate is 1.6-fold (0.20 log units) below it; low and high end bracket the measured number.
By their numbers in this assay, from the lowest: compounds 3, 2, 1 and 4 (each within the scatter of the next).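

The dimethylamino compound extends the series to a nitrogen with no hydrogen left on it, and in this assay the second methyl still gives only a step within the scatter (a 1.8-fold higher number from compound 3 to compound 4 (0.24 log units; within the scatter)). Replacing the whole amine group shows the same picture, with dimethylamino in place of amino (a 1.6-fold higher number from compound 2 to compound 4 (0.20 log units; within the scatter)) and in place of isopropylamino (no change at the digits printed from compound 1 to compound 4 (within the scatter)) both within the scatter, so all four substitution patterns on this nitrogen remain inseparable on these numbers, and none of the four compounds goes against this. No supporting measurement is available that could account for how these four numbers fall.

The compounds shown leave open whether a larger group on this nitrogen, such as a benzyl or a longer chain like n-butyl, or a nitrogen held in a ring such as pyrrolidine or morpholine, would move the number in this assay beyond the scatter. Also open, from the compounds shown here alone, is whether replacing the amine on the saturated chain carbon with a hydroxyl or an amide would do so, since every compound here keeps a basic-free reading of nothing more than an amine at that place.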